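The source may hold more compounds than are shown below. What is called first, only, known or untested is meant among the compounds shown, and "the series" means these compounds.

Three amides sharing one core have been measured in a functional assay on PC-3 cells (Homo sapiens) for inhibition, read by sulforhodamine B assay, with a stated time of 72 h; a higher number here means a weaker inhibitor, a lower number a stronger inhibitor. Compound 1 `Nc1sc(-c2ccc(Cl)cc2)c(-c2ccc(Cl)cc2)c1C(=O)N1CCCC1` gives 6220 nM, compound 2 `Nc1sc(-c2ccc(Cl)cc2)c(-c2ccc(Cl)cc2)c1C(=O)NC1CCC(O)CC1` gives 5670 nM, and compound 3 `Nc1sc(-c2ccc(Cl)cc2)c(-c2ccc(Cl)cc2)c1C(=O)N1CCNCC1` gives 2710 nM. Compound 2 thus holds the second highest of the three numbers: the three steps are a 1.1-fold lower number from compound 1 to compound 2 (0.04 log units; within the scatter), a 2.1-fold lower number from compound 2 to compound 3 (0.32 log units; beyond the scatter), and a 2.3-fold lower number from compound 1 to compound 3 (0.36 log units; beyond the scatter).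

Compound 4 `Nc1sc(-c2ccc(Cl)cc2)c(-c2ccc(Cl)cc2)c1C(=O)NC1CCCC1` is the next step from compound 2. The change is cyclopentyl in place of 4-hydroxycyclohexyl on an amide-type nitrogen. Going by the values given here, no measured pair removes a hydroxyl in this way, so the nearest guide is the comparison of compound 1 with compound 2, where a pyrrolidin-1-yl amide without donor or acceptor and the (4-hydroxycyclohexyl)amino amide sit within the scatter of each other. A step no larger than the scatter is therefore expected, in no clear direction. The estimate for compound 4 is 6500 nM, with a range from 3000 nM to 14000 nM, which corresponds to an expected step of a 1.1-fold higher number from compound 2 to compound 4 (0.06 log units; within the scatter).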

Compound 4, half-maximal inhibitory concentration: 21200 nM
Compound 4: the middle estimate sits 3.3-fold (0.51 log units) below what was measured; the whole stated range lies below it.
By their numbers in this assay, from the lowest: compound 3; then compounds 2 and 1 (each within the scatter of the next); then compound 4.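

Replacing 4-hydroxycyclohexyl with cyclopentyl on the amide-type nitrogen is not a silent change in this assay: the number shifts beyond the scatter, with a 3.7-fold higher number from compound 2 to compound 4 (0.57 log units; beyond the scatter) in this single exchange. Compound 4 is the weakest of the four amides, as shown by a 3.4-fold higher number from compound 1 to compound 4 (0.53 log units; beyond the scatter) and by a 7.8-fold higher number from compound 3 to compound 4 (0.89 log units; beyond the scatter), so the closeness of compound 1 and compound 2 gave no guide to what this position tolerates. No measurement shown here explains the step.

The exchange alters the ring size and removes the hydroxyl together, so the compounds shown leave open which of the two carries the step. An unsubstituted cyclohexyl amide would separate them, and a 4-aminocyclohexyl amide would show whether another group can stand in place of the hydroxyl.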